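The compounds below may be only part of what the source reports. "The series", "measured", "known", "first", "only" and "open" are said of these compounds alone.

Of the compounds shown here, three share one core and have been measured so far. Compound 1 `CCCN1CCCN(c2nc3ccccc3n2CCOCC)CC1` gives 8.4 nM in a functional assay on ileum for inhibition of histamine H1 receptor (Cavia porcellus); on this read-out higher numbers stand for weaker inhibition and lower numbers for stronger inhibition; compound 2 `CCCCN1CCCN(c2nc3ccccc3n2CCOCC)CC1` gives 8.4 nM; compound 3 `CCOCCn1c(N2CCCN(Cc3ccccc3)CC2)nc2ccccc21` gives 15 nM. On these numbers compound 3 has the highest of the three, though neither gap exceeds the scatter: a 1.8-fold higher number from compound 1 to compound 3 (0.25 log units; within the scatter) and a 1.8-fold higher number from compound 2 to compound 3 (0.25 log units; within the scatter). Nor did the change between the two chain compounds move the number, no change at the digits printed from compound 1 to compound 2 (within the scatter).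

Compound 4 `CCCCCN1CCCN(c2nc3ccccc3n2CCOCC)CC1` has not yet been measured in this assay. Its difference from compound 3 is butyl in place of phenyl on a saturated chain carbon bound to an amine nitrogen in a ring. This is the reverse of the two steps already seen, in which ethyl or propyl gave way to phenyl without shifting the number beyond the scatter, so the step back to an alkyl chain is expected to bring little or no change in this assay, and certainly nothing beyond the scatter in either direction. Compound 4 is therefore estimated at 9 nM, with a range from 4 nM to 20 nM, an expected step of a 1.7-fold lower number from compound 3 to compound 4 (0.22 log units; within the scatter).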

Compound 4, half-maximal inhibitory concentration: 7.4 nM
Beside the measured number, compound 4's estimate is 1.2-fold (0.09 log units) above it; low and high end bracket the measured number.
By their numbers in this assay, from the lowest: compounds 4, 1, 2 and 3 (each within the scatter of the next, the first and the last beyond it).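

Butyl in place of phenyl, on a saturated chain carbon bound to an amine nitrogen in a ring, gives a 2.0-fold lower number from compound 3 to compound 4 (0.31 log units; beyond the scatter), the first step in this assay to pass the scatter, though only a modest one. The pentyl of compound 4 stays within the scatter of the two other chain compounds, with a 1.1-fold lower number from compound 2 to compound 4 (0.06 log units; within the scatter) and a 1.1-fold lower number from compound 1 to compound 4 (0.06 log units; within the scatter), so this series shows no effect of chain length, and the benzyl of compound 3 stands apart only from compound 4, not from compound 1 or compound 2. Nothing in the data at hand accounts for the step from compound 3 to compound 4.

As far as these compounds go, it remains open whether a longer chain, a branched chain or a chain ending in an amine would stay within the scatter of compound 4. Also open, from the compounds shown here alone, is how cyclohexylmethyl, or a benzyl carrying a fluorine or a methoxy group, would compare with compound 3.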